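The source may hold more compounds than are shown below. What is called first, only, known or untested is meant among the compounds shown, and "the series" means these compounds.

Measured compounds:

Compound 1 `CCCCn1c(-c2ccc(OC)cc2)cnc1NC(=O)c1ccc(F)cc1` — in a toxicity assay on THP-1 cells (Homo sapiens) for inhibition (a lower number here means that less compound is tolerated, a higher number that more compound is tolerated), compound 1 gives > 100000 nM, which is a limit of the assay and not a number.

Compound 2 `COc1ccc(-c2cnc(NC(=O)c3ccc(Cl)cc3)n2C)cc1` — in this assay compound 2 gives > 100000 nM, again a limit and not a number.

Compound 1 therefore stands at the limit of > 100000 nM in this assay, at which 2 of the 2 values shown sit. Nothing more is known of its position, since only a limit and no number was obtained for it, and the second value shown is a limit as well. Within the data shown here, no step between measured compounds is available, so no measured change in this read-out can be described.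

The unmeasured compound 3 `COc1ccc(-c2cnc(NC(=O)c3ccc(F)cc3)n2-c2ccccc2)cc1` is the next step from compound 1. The change is phenyl in place of butyl on an aromatic nitrogen.

Because compound 1 sits at the limit of > 100000 nM in this assay, at which 2 of the 2 values shown sit, there is no room for a clear direction to be read. Compound 3 is expected to give about 100000 nM, most probably again reported only as a limit, with a range from 50000 nM to 300000 nM. The step that this estimate implies is a number no higher from compound 1 to compound 3 (the limit leaves the size open), which is expected to be none beyond the usual scatter.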

Compound 3, half-maximal cytotoxic concentration: 8800 nM
For compound 3 the middle estimate is 11-fold (1.06 log units) above the measured one, outside the stated range (below it).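

The nitrogen that carries the butyl group of compound 1 turns out to matter in this assay: phenyl in place of butyl at this position gives an at least 11-fold lower number from compound 1 to compound 3 (1.05 log units; beyond the scatter). Among these compounds, this is the first sign that the read-out responds to any change, and compound 3 is the only one of the three compounds with a value that is a number and not a limit. Compound 1 and compound 2 could not show this on their own, since neither gives a number and they differ in more than one place, and the position of the series in this assay was defined by a single ceiling: the limit of > 100000 nM in this assay, at which 2 of the 3 values shown sit.

Going by these compounds, what remains open is whether the drop follows from the aromatic ring itself or simply from a larger group on this nitrogen, a question that a cyclohexyl or a benzyl group at the same position would address. On these data alone, it is also open how substituents on the new phenyl ring, such as a methoxy group or an amine, would shift the value, and how far the step truly reaches, given that the value of compound 1 is only a limit.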